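This account rests on a few compounds, and the source may have more. Where it says the series, first, only, none or still open, it means among the compounds named here.

Compound 1 `COCCNC(=C\C(=O)/C=C/c1ccc(O)cc1)/C=C/c1ccc(O)cc1` and compound 3 `COCCCNC(=C\C(=O)/C=C/c1ccc(O)cc1)/C=C/c1ccc(O)cc1` share one core and differ only in a single chain. In a functional assay, read by spectrophotometry, with a stated time of 30 min (a higher number here means that more compound is needed for the effect, a lower number that less compound is needed), compound 1 gives > 200000 nM, which is a limit of the assay rather than a number. Compound 3 gives 130000 nM in this assay. The change between them is methoxymethyl in place of methoxy on a saturated chain carbon, two bonds along the chain from an amine nitrogen, and it made an at least 1.5-fold lower number from compound 1 to compound 3 (0.18 log units; that floor lies within the scatter); that step is known only as a floor due to the limit of > 200000 nM in this assay, at which 1 of the 3 values shown sits. Compound 2 `COCCNC(=C\C(=O)/C=C/c1ccc(O)c(OC)c1)/C=C/c1ccc(O)c(OC)c1` has a different core, and how its core differs from that of compound 1 is not broken down here. In this assay compound 2 gives 27300 nM, the lowest of the two numbers obtained so far. Compound 4 `COCCCNC(=C\C(=O)/C=C/c1ccc(O)c(OC)c1)/C=C/c1ccc(O)c(OC)c1` is not yet measured; it differs from compound 2 by methoxymethyl in place of methoxy on a saturated chain carbon, two bonds along the chain from an amine nitrogen, the same change as from compound 1 to compound 3, at the same place. Since that change gave an at least 1.5-fold lower number from compound 1 to compound 3 (0.18 log units; that floor lies within the scatter), a step of similar, modest size is expected here, read as a 1.4-fold lower number from compound 2 to compound 4 (0.14 log units; within the scatter). Compound 4 is therefore estimated at 20000 nM in this assay, expected to fall between 8000 nM and 50000 nM.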

Compound 4, half-maximal effective concentration in the functional assay: 29500 nM
For compound 4 the middle estimate is 1.5-fold (0.17 log units) below the measured one; the range from low to high includes it.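

In the functional assay, going from 2-methoxyethyl to 3-methoxypropyl on the core of compound 2 gives a 1.1-fold higher number from compound 2 to compound 4 (0.03 log units; within the scatter), so these two compounds cannot be told apart here. Set beside the earlier step on the core of compound 1, this shows no clear difference between the two cores, and neither step shows a clear effect of the change: the same change on two cores in the functional assay, an at least 1.5-fold lower number (0.18 log units; that floor lies within the scatter) from compound 1 to compound 3 and a 1.1-fold higher number (0.03 log units; within the scatter) from compound 2 to compound 4; the limit leaves it open whether they differ The value of compound 1 is a limit and not a number, so the true size of the earlier step stays unknown, and the data do not show that the change acts alike on both cores: the limit of > 200000 nM in the functional assay, at which 1 of the 4 values shown sits.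

In a physicochemical assay for solubility, using the shake flask method, in phosphate buffer, with a stated time of 90 min, at pH 6.8 (on this read-out lower numbers stand for lower solubility and higher numbers for higher solubility), compound 2 gives 16700 nM and compound 4 gives 7700 nM. From the compounds shown here alone, it remains open whether the lower value seen in the physicochemical assay would hold on another core: the measured solubility of compound 2, 16700 nM, and of compound 4, 7700 nM, a 2.2-fold lower number (0.34 log units; beyond the scatter) Also open is how a longer chain, or an amine or a carboxylic acid in place of the methoxy group, would behave in the functional assay.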